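The source may hold more compounds than are shown below. What is called first, only, known or untested is meant among the compounds shown, and "the series" means these compounds.

Compound 1 `O=C(Nc1ccc(-n2ncc3c(Br)cccc32)cc1)Nc1ccc(Cl)c(C(F)(F)F)c1` is the stronger of the two measured compounds in a functional assay on OS-RC-2 cells (Homo sapiens) for cytotoxicity, read by MTT assay, with a stated time of 72 h; on this read-out higher numbers stand for weaker inhibition and lower numbers for stronger inhibition: compound 1 gives 9900 nM, whereas compound 2 `O=C(Nc1ccc(-n2ncc3ccccc32)cc1)Nc1ccc(Cl)c(C(F)(F)F)c1` gives 32000 nM. Among the measured compounds shown here, the only measured step here is a 3.2-fold higher number from compound 1 to compound 2 (0.51 log units; beyond the scatter), so taking the bromo away weakens inhibition by a modest but real margin. Compound 3 `COc1cccc2c1cnn2-c1ccc(NC(=O)Nc2ccc(Cl)c(C(F)(F)F)c2)cc1` differs from compound 1 by methoxy in place of bromo on an aromatic carbon. For the measured compounds named here, no measured pair shows what a methoxy does at this position; the single step from compound 1 to compound 2 only shows that the bromo contributes to the potency of compound 1. A methoxy is a different group from hydrogen, so the outcome is uncertain, but with the bromo gone the most likely result is a rise in the number of a size close to that seen on removing it, and the estimate for compound 3 is a 1.8-fold higher number from compound 1 to compound 3 (0.26 log units; within the scatter). Compound 3 is therefore expected to give about 18000 nM in this assay, within a range from 7000 nM to 45000 nM.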

Compound 3, half-maximal inhibitory concentration: 28800 nM
Compound 3: middle estimate off by 1.6-fold (0.20 log units), on the low side; the measured number falls inside the stated range.
By their numbers in this assay, from the lowest: compound 1; then compounds 3 and 2 (each within the scatter of the next).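

In this assay, methoxy in place of bromo on this aromatic carbon does not keep the potency of compound 1, with a 2.9-fold higher number from compound 1 to compound 3 (0.46 log units; beyond the scatter). Methoxy in place of hydrogen gives a 1.1-fold lower number from compound 2 to compound 3 (0.05 log units; within the scatter), so compound 3 and compound 2 cannot be told apart here, and among bromo, methoxy and hydrogen at this position, only bromo gives a clear gain. Nothing measured here explains why bromo and methoxy differ.

As far as these compounds go, three groups at one position cannot show what the gain with bromo depends on, so it remains open whether chloro or iodo would match bromo here. An amine or a longer chain such as ethoxy could also be placed on this carbon, and its effect on the number cannot be predicted from these compounds.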